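Ester Variation and Half-life in Simulated Gastric Fluid

The source may hold more compounds than are shown below. What is called first, only, known or untested is meant among the compounds shown, and "the series" means these compounds.

Compound 1 `CCOc1cc(NC(=O)C2(NC(=O)c3ccc4c(C5CCCC5)c(-c5ncc(Cl)cn5)n(C)c4c3)CCC2)ccc1/C=C/C(=O)N[C@@H](CCC(=O)O)C(N)=O`: 0.533 h
Compound 2 `CCOc1cc(NC(=O)C2(NC(=O)c3ccc4c(C5CCCC5)c(-c5ncc(Cl)cn5)n(C)c4c3)CCC2)ccc1/C=C/C(=O)OCOP(=O)(O)O`: 1.3 h

Of the two measured compounds, compound 2 holds the higher number in an ADME assay on stomach for pharmacokinetics, in simulated gastric fluid; a lower number here means that the compound disappears faster, a higher number that the compound lasts longer: compound 2 gives 1.3 h, whereas compound 1 gives 0.533 h. Within the data shown here, the only measured step between them is a 2.4-fold higher number from compound 1 to compound 2 (0.39 log units; beyond the scatter), a modest rise.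

Compound 3 `CCOc1cc(NC(=O)C2(NC(=O)c3ccc4c(C5CCCC5)c(-c5ncc(Cl)cn5)n(C)c4c3)CCC2)ccc1/C=C/C(=O)OCC(C)C` differs from compound 2 by a group of 3 heavy atoms (3 carbon; no ring) in place of a group of 5 heavy atoms (4 oxygen, 1 phosphorus; no ring), on a saturated chain carbon bound to an oxygen next to a carbonyl group. Among the measured compounds shown here, the one measured step replaced the whole group on the carbonyl carbon, while the change to compound 3 keeps the ester and alters only the part named in that difference; it therefore bears on the new step only loosely, and no closer precedent exists among the measured compounds.

With that single, indirect guide, a modest rise is expected for compound 3 in this assay, a 1.5-fold higher number from compound 2 to compound 3 (0.19 log units; within the scatter), though a result within the scatter of compound 2 remains quite possible. Compound 3 is therefore estimated at 2 h, with a range from 0.8 h to 5 h.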

Compound 3, half-life: 1.43 h
Compound 3: the middle estimate sits 1.4-fold (0.15 log units) above what was measured; the range from low to high includes it.
By their numbers in this assay, from the lowest: compound 1; then compounds 2 and 3 (each within the scatter of the next).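

In this assay, isopropyl in place of the group of 5 heavy atoms (4 oxygen, 1 phosphorus), on a saturated chain carbon bound to an oxygen next to a carbonyl group, gives a 1.1-fold higher number from compound 2 to compound 3 (0.04 log units; within the scatter) and so does not separate the two compounds. At this place, a group with 2 hydrogen-bond donors and an isopropyl with none therefore give half-lives that cannot be told apart, a point the earlier pair could not show. Isobutoxy in place of (1-carbamoyl-3-carboxypropyl)amino on a carbonyl carbon gives a 2.7-fold higher number from compound 1 to compound 3 (0.43 log units; beyond the scatter) and stands with a 2.4-fold higher number from compound 1 to compound 2 (0.39 log units; beyond the scatter) as a second step beyond the scatter, so both esters shown lie on the same side of the amide.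

Nothing shown accounts for these numbers, and the reason for them remains unknown. Still open, on these data alone, is whether an amine, a carboxylic acid or a longer chain on that saturated chain carbon would move the result in this assay beyond the scatter, and whether any such group would bring it closer to the amide.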